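Fused bicyclic group in place of pyridyl on the shared core

This account rests on a few compounds, and the source may have more. Where it says the series, first, only, none or still open, it means among the compounds named here.

Measured in a physicochemical assay for lipophilicity, read by HPLC; on this read-out higher numbers stand for higher lipophilicity and lower numbers for lower lipophilicity:
compound 1 `N#Cc1cnc(-c2ccccc2)nc1N1C[C@@H]2C[C@H]1CN2c1cccc(F)c1` — 4.5
compound 2 `N#Cc1cnc(-c2cccnc2)nc1N1C[C@@H]2C[C@H]1CN2c1cccc(F)c1` — 3.43
compound 3 `N#Cc1cnc(-c2cccnc2)nc1N1C[C@@H]2C[C@H]1CN2c1cccc(Cl)c1` — 3.82

Compound 2 holds the lowest of the three numbers in this assay; the nearest neighbour is given by a number 0.39 log units higher from compound 2 to compound 3 (beyond the scatter), the furthest by a number 1.07 log units lower from compound 1 to compound 2 (beyond the scatter).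

Compound 4 `N#Cc1cnc(-c2ccnc3[nH]ccc23)nc1N1C[C@@H]2C[C@H]1CN2c1cccc(F)c1` is not yet measured. Its change from compound 2: a group of 9 heavy atoms (7 carbon, 2 nitrogen; one five-membered aromatic ring with 1 hetero atom, one six-membered aromatic ring with 1 hetero atom) in place of a group of 6 heavy atoms (5 carbon, 1 nitrogen; one six-membered aromatic ring with 1 hetero atom), on an aromatic carbon.

Of the measured steps, a number 1.07 log units lower from compound 1 to compound 2 (beyond the scatter) touches the same aromatic carbon and was large; a number 0.39 log units higher from compound 2 to compound 3 (beyond the scatter) lies at another place and was modest. The entering group keeps a six-membered aromatic ring with one hetero atom and adds a five-membered aromatic ring carrying one hydrogen-bond donor, so a moderate rise in this assay is expected, a number 0.57 log units higher from compound 2 to compound 4 (beyond the scatter). Compound 4 is estimated at 4, range 3.4 to 4.6.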

Compound 4, distribution coefficient: 3.4
The estimate for compound 4 lay 0.60 log units above the measured number; measured number inside the range.
By their numbers in this assay, from the lowest: compounds 4 and 2 (each within the scatter of the next); then compound 3; then compound 1.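

In this assay the larger fused group on this aromatic carbon, with its added five-membered aromatic ring and hydrogen-bond donor, gives a number 0.03 log units lower from compound 2 to compound 4 (within the scatter), so pyridin-3-yl and this group cannot be told apart here. Against phenyl the same group gives a number 1.10 log units lower from compound 1 to compound 4 (beyond the scatter), a large step, as pyridin-3-yl also gave with a number 1.07 log units lower from compound 1 to compound 2 (beyond the scatter). No measured evidence bears on this result.

Still open, as far as these compounds go, is whether the fused group behaves alike with chloro in place of fluoro, and how an amine or carboxylic acid on this aromatic carbon would read.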